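Piperidinyl urea replaces acetamide on the sulfonamide arm

This account rests on a few compounds, and the source may have more. Where it says the series, first, only, none or still open, it means among the compounds named here.

Compound 1 `O=C(Nc1ccc(-c2noc(-c3cccc(NS(=O)(=O)c4ccccc4)c3)n2)c(Cl)c1)c1cccnc1` gives in a functional assay on MDA-MB-231 cells (Homo sapiens) for antiproliferative activity, read by MTT assay, with a stated time of 72 h (a higher number here means a weaker inhibitor, a lower number a stronger inhibitor), only a limit, > 10000 nM.
Compound 2 `CC(=O)Nc1ccc(S(=O)(=O)Nc2cccc(-c3nc(-c4ccc(NC(=O)c5cccnc5)cc4Cl)no3)c2)cc1` gives in this assay 2500 nM.

Compound 2 holds the only number shown in this assay; the value for compound 1 is a limit (the limit of > 10000 nM in this assay, at which 1 of the 2 values shown sits). Within the data shown here, the one measured step, an at least 4.0-fold lower number from compound 1 to compound 2 (0.60 log units; beyond the scatter), reads as a lower number once acetamido enters. Compound 3 `O=C(Nc1ccc(-c2noc(-c3cccc(NS(=O)(=O)c4ccc(NC(=O)N5CCCCC5)cc4)c3)n2)c(Cl)c1)c1cccnc1` differs from compound 2 by piperidin-1-yl in place of methyl on a carbonyl carbon. Among the measured compounds shown here, that step bears on the same arm, but no measured pair shows piperidin-1-yl against methyl there, so compound 3 is expected to stay near compound 2, with a step of a 1.3-fold lower number from compound 2 to compound 3 (0.10 log units; within the scatter). For compound 3 the estimate is 2000 nM, ranging from 500 nM to 8000 nM.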

Compound 3, half-maximal inhibitory concentration: > 10000 nM
Compound 3: no number, only a limit; the forecaster's own chance of this, stated with the estimate: 15%; middle value at least 5.0-fold (0.69 log units) away from the limit.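

On a carbonyl carbon whose other neighbour is an amide-type nitrogen, the change from methyl to piperidin-1-yl is not neutral in this assay: it gives an at least 4.0-fold higher number from compound 2 to compound 3 (0.60 log units; beyond the scatter). The lower number brought by acetamido therefore does not extend to ((piperidin-1-yl)carbonyl)amino on the same arm. Compound 3 joins compound 1 at a limit, so the step between those two cannot be read: the limit of > 10000 nM in this assay, at which 2 of the 3 values shown sit.

The compounds shown leave open whether ethyl, dimethylamino or pyrrolidin-1-yl on that carbonyl carbon would keep the number of compound 2. They also leave open whether the change in compound 3 follows from the ring or from the added nitrogen.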